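Working Notes: From Compound 1 to Compound 4

This account rests on a few compounds, and the source may have more. Where it says the series, first, only, none or still open, it means among the compounds named here.

Compound 1 `CNC(=O)COc1ccncc1-c1ccc2ccccc2c1` carries a (methylcarbamoyl)methoxy group on the shared core. For compound 1 in a functional assay on HCT-116 cells (Homo sapiens) for inhibition, read by MTT assay, with a stated time of 72 h (on this read-out lower numbers stand for stronger inhibition of growth and higher numbers for weaker inhibition of growth), no result is reported, "not determined" (no result reported). Compound 2 `O=C(/C=C/c1ccncc1-c1ccc2cccnc2c1)N1CCOCC1` likewise has no result in this assay, "not determined" (no result reported). Compound 3 `Cn1ncc2cc(-c3cnccc3/C=C/C(=O)O)ccc21` returns in this assay only a limit of the assay, > 30000 nM. Among the measured compounds shown here, compound 1 therefore stands without a single number; of the two further entries one is a limit and one has no number at all, so no measured step exists and the only numerical mark in the set is the limit of > 30000 nM in this assay, at which 1 of the 3 values shown sits.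

Compound 4 `CN(C)C(=O)/C=C/c1ccncc1-c1ccc2ccccc2c1` differs from compound 1 in one place: 2-(dimethylcarbamoyl)ethenyl in place of (methylcarbamoyl)methoxy on an aromatic carbon. For the measured compounds named here, with no step between measured compounds to lean on, the size of the change in this assay cannot be read from the data, and no direction beyond the usual scatter can be claimed for the step from compound 1 to compound 4. Compound 3 gives only a limit in this assay, > 30000 nM. On that thin basis weak growth inhibition is expected for compound 4, estimated at 15000 nM with a range from 3000 nM to 100000 nM, and a sizeable chance that the assay again reports only a limit.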

Compound 4, concentration for 50% growth inhibition: 4540 nM
Beside the measured number, compound 4's estimate is 3.3-fold (0.52 log units) above it; low and high end bracket the measured number.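

No new step can be read in this assay: compound 4 gives 4540 nM, while compound 1 has no single number to set against it. The compounds shown leave open how far, and in which direction, 2-(dimethylcarbamoyl)ethenyl in place of (methylcarbamoyl)methoxy moves growth inhibition on the shared core, and the only other mark remains a limit: the limit of > 30000 nM in this assay, at which 1 of the 4 values shown sits.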